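This account rests on a few compounds, and the source may have more. Where it says the series, first, only, none or still open, it means among the compounds named here.

Measured in a functional assay on NTUB1 cells (Homo sapiens) for cytotoxicity, read by MTT assay, with a stated time of 72 h; a lower number here means a stronger inhibitor, a higher number a weaker inhibitor:
- compound 1 `COc1ccc(OC)c(C(=O)/C=C/c2ccc(C(=O)OCc3ccccc3)cc2)c1`: 13300 nM
- compound 2 `CCCNC(=O)c1ccc(/C=C/C(=O)c2cc(OC)ccc2OC)cc1`: 2260 nM

Of these two, compound 2 has the lower number, at 2260 nM, and so is the stronger inhibitor. The next structure, compound 3 `COc1ccc(OC)c(C(=O)/C=C/c2ccc(C(=O)N3CCCC3)cc2)c1`, has pyrrolidin-1-yl in place of propylamino on a carbonyl carbon, a change counted as pyrrolidin-1-yl in place of propylamino on a carbonyl carbon. Among the measured compounds shown here, no measured step covers this exchange. For the measured compounds named here, the only measured step that bears on it is a 5.9-fold lower number from compound 1 to compound 2 (0.77 log units; beyond the scatter), which changed a group on the same carbonyl carbon but involved a different pair of groups. It therefore offers only a loose guide to size and none to direction. A modest move towards a higher number is tentatively expected, with a wide margin in either direction. The expected change is a 1.5-fold higher number from compound 2 to compound 3 (0.19 log units; within the scatter). For compound 3 the estimated value in this assay is 3500 nM, with an expected range from 1300 nM to 10000 nM.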

Compound 3, half-maximal inhibitory concentration: 1260 nM
For compound 3 the middle estimate is 2.8-fold (0.44 log units) above the measured one; the measured number lies below the stated range.
By their numbers in this assay, from the lowest: compounds 3 and 2 (each within the scatter of the next); then compound 1.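

In this assay, the exchange of propylamino for pyrrolidin-1-yl gives a 1.8-fold lower number from compound 2 to compound 3 (0.25 log units; within the scatter), so closing a five-membered ring and dropping the hydrogen-bond donor counted on propylamino leave the two groups indistinguishable on this carbonyl carbon. Replacing benzyloxy with pyrrolidin-1-yl gives an 11-fold lower number from compound 1 to compound 3 (1.02 log units; beyond the scatter), and together with a 5.9-fold lower number from compound 1 to compound 2 (0.77 log units; beyond the scatter) this shows that two different nitrogen-linked groups on this carbon both stand clear of benzyloxy, with no compound shown going against that pattern. Nothing available accounts for either result.

The compounds shown leave open how a piperidin-1-yl or morpholin-4-yl ring, or a chain longer than propyl on the nitrogen, would read on this carbonyl carbon. They also leave open whether a free carboxylic acid there would fall with benzyloxy or with the nitrogen-linked groups.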